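Ethylpiperazine Analogues in the Liver-Cell Growth Assay

This account rests on a few compounds, and the source may have more. Where it says the series, first, only, none or still open, it means among the compounds named here.

Compound 1 `Cc1ccccc1Nc1nc(Nc2ccc(N3CCN(C)CC3)cn2)ncc1Cl` is measured in an ADME assay on L02 cells (Homo sapiens) for inhibition, read by CCK-8 assay, with a stated time of 48 h (on this read-out higher numbers stand for weaker inhibition of growth and lower numbers for stronger inhibition of growth), where compound 1 gives 5980 nM. Compound 2 `CCN1CCN(c2ccc(Nc3ncc(Cl)c(Nc4ccccc4C)n3)nc2)CC1` reaches only the limit of this assay and is reported as > 100000 nM, a limit rather than a number. The change from compound 1 to compound 2 is methyl in place of hydrogen on a saturated chain carbon bound to an amine nitrogen in a ring, and it brought an at least 16-fold higher number from compound 1 to compound 2 (1.22 log units; beyond the scatter); one of the three values shown sits at the limit of > 100000 nM in this assay, at which 1 of the 3 values shown sits.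

Compound 3 `Cc1ccccc1Nc1nc(Nc2ccc(N3CCN(C)CC3)cc2)ncc1Cl` gives 6510 nM in this assay, a value within the scatter of the value of compound 1, so the two are not told apart. The difference between the core of compound 3 and the core of compound 1 is not broken down here.

Compound 4 `CCN1CCN(c2ccc(Nc3ncc(Cl)c(Nc4ccccc4C)n3)cc2)CC1` is not yet measured. It differs from compound 3 by methyl in place of hydrogen on a saturated chain carbon bound to an amine nitrogen in a ring, the same change that separates compound 1 from compound 2, made at the same place. The step in this assay is therefore expected to be a large rise, a 15-fold higher number from compound 3 to compound 4 (1.19 log units; beyond the scatter), resting on an at least 16-fold higher number from compound 1 to compound 2 (1.22 log units; beyond the scatter) seen for compound 2. On that basis compound 4 is estimated at 100000 nM, with a fair chance that only a limit is reported.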

Compound 4, concentration for 50% growth inhibition: 970 nM
For compound 4 the middle estimate is 100-fold (2.01 log units) above the measured one; the measured number lies below the stated range.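

In this assay, the change from 4-methylpiperazin-1-yl to 4-ethylpiperazin-1-yl gives a 6.7-fold lower number from compound 3 to compound 4 (0.83 log units; beyond the scatter), so the rise seen on the core of compound 1 does not carry over to the core of compound 3, and the two steps run in opposite directions: the same change on two cores in this assay, an at least 16-fold higher number (1.22 log units; beyond the scatter) from compound 1 to compound 2 and a 6.7-fold lower number (0.83 log units; beyond the scatter) from compound 3 to compound 4, at least 110-fold (2.05 log units) apart, beyond the scatter of two such steps

Compound 2 stands at > 100000 nM, which is a limit of the assay and not a number. The two pairs show that, in this series, a step measured on one core is no safe guide to the same change on the other, but they do not show which difference between the cores goes with the gap, how large the step to compound 2 truly is, or how other pairs would behave.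

Still open, as far as these compounds go, is whether a longer chain, such as propyl, or a 2-hydroxyethyl group in place of the ethyl would split the two cores in the same way. Equally open, from the compounds shown here alone, is whether the lower number of compound 4 would persist with such groups or is confined to the ethyl.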